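Swapping chloro for methoxy on the benzoyl ring

This account rests on a few compounds, and the source may have more. Where it says the series, first, only, none or still open, it means among the compounds named here.

Compound 1 (`Cc1ccc(N(CCN2CCC(OCC(=O)O)CC2)C(=O)c2ccc(F)cc2)cc1`) gives 970 nM in this series
Compound 2 (`Cc1ccc(N(CCN2CCC(OCC(=O)O)CC2)C(=O)c2ccc(Cl)cc2)cc1`) gives 690 nM in this series

Going by the values given here, on a functional assay on a cell-free system (Platelet, plasma, Homo sapiens) for inhibition (on this read-out higher numbers stand for weaker inhibition and lower numbers for stronger inhibition), compound 2 stands level with compound 1: the only measured step is a 1.4-fold lower number from compound 1 to compound 2 (0.15 log units; within the scatter) and it exchanges one halogen for another. Compound 3 (`COc1ccc(C(=O)N(CCN2CCC(OCC(=O)O)CC2)c2ccc(C)cc2)cc1`) has not been measured yet. It keeps the core of compound 2 but carries methoxy in place of chloro on an aromatic carbon, para to a large group (methoxy in place of chloro on an aromatic carbon). Among the compounds with values here, only that single step from compound 1 to compound 2 bears on this change, and no measured compound carries a methoxy, so the data offer no direction. No step beyond the scatter is expected on this assay here. The estimated change is a 1.2-fold higher number from compound 2 to compound 3 (0.06 log units; within the scatter) and no larger shift can be argued from two values. For compound 3 the estimate is 800 nM with an expected range of 300 nM to 2000 nM in this read-out.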

Compound 3, half-maximal inhibitory concentration: 1200 nM
Estimate against measurement, compound 3: 1.5-fold (0.18 log units) below; measured number inside the range.
By their numbers in this assay, from the lowest: compounds 2, 1 and 3 (each within the scatter of the next).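

In this assay methoxy in place of chloro gives a 1.7-fold higher number from compound 2 to compound 3 (0.24 log units; within the scatter) and methoxy in place of fluoro gives a 1.2-fold higher number from compound 1 to compound 3 (0.09 log units; within the scatter) (both within the scatter). The position para to a large group therefore now has a reading for a group that is not a halogen: methoxy brings an oxygen and a hydrogen-bond acceptor, yet compound 3 cannot be told apart from compound 1 or compound 2 on this read-out. No measurement here gives a reason for this result.

Still open, from the compounds shown here alone, is whether a different group at this position, such as an amine, a nitrile or a longer alkoxy chain, would give a step beyond the scatter. The compounds shown also leave open whether methoxy would read the same way on a different core.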